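Removing the 4-fluorophenyl ring from compound 2

The source may report more compounds than this note shows. Statements on the series, on what has been measured and on what is new or still open speak of the compounds shown alone.

Compound 2 `Nc1ccc(/C=C2\SC(=O)N(Cc3ccc(F)cc3)C2=O)cc1` gives 36000 nM in a functional assay on FM3A cells (Mus musculus) for cytotoxicity, read by cell counting, with a stated time of 2 days (a higher number here means a weaker inhibitor, a lower number a stronger inhibitor), the lowest of the two numbers shown; its only neighbour, compound 1 `CC(C)(C)c1ccc(CN2C(=O)S/C(=C\c3ccc(N)cc3)C2=O)cc1`, gives 80000 nM, and the two are separated by a 2.2-fold lower number from compound 1 to compound 2 (0.35 log units; beyond the scatter). Compound 3 `CN1C(=O)S/C(=C\c2ccc(N)cc2)C1=O` has not been measured. It differs from compound 2 by hydrogen in place of 4-fluorophenyl on a saturated chain carbon bound to an amide-type nitrogen in a ring, so the whole ring that carried the fluoro in compound 2 and the tert-butyl in compound 1 is gone. Going by the values given here, the one measured step, a 2.2-fold lower number from compound 1 to compound 2 (0.35 log units; beyond the scatter), concerns only the substituent on that ring and says nothing about its removal; no step bears directly on this change. Because compound 2 itself gives only 36000 nM, compound 3 is expected to remain a weak inhibitor, most likely with a somewhat higher number. The expected step is a 1.9-fold higher number from compound 2 to compound 3 (0.29 log units; within the scatter). Compound 3 is estimated at 70000 nM, within 20000 nM to 250000 nM.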

Compound 3, half-maximal inhibitory concentration: 107000 nM
Compound 3: the middle estimate sits 1.5-fold (0.18 log units) below what was measured, within the range that was stated.
By their numbers in this assay, from the lowest: compound 2; then compounds 1 and 3 (each within the scatter of the next).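

Removing the 4-fluorophenyl from the saturated chain carbon bound to an amide-type nitrogen in a ring gives a 3.0-fold higher number from compound 2 to compound 3 (0.47 log units; beyond the scatter) in this assay, so this aromatic ring, and not only its substituent, bears on the number. The ring does not separate from hydrogen in every form: compound 1 gives 80000 nM and compound 3 gives 107000 nM, values within the scatter of each other. No measurement in hand accounts for this step.

The compounds shown leave open whether an unsubstituted phenyl ring, a chloro or methoxy group in place of the fluoro, or a plain butyl chain at this position would read like compound 2 or like compound 3. They also leave open whether this order holds outside this assay.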